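The source may hold more compounds than are shown below. What is called first, only, known or untested is meant among the compounds shown, and "the series" means these compounds.

Among the measured compounds shown here, in a functional assay on A549 cells (Homo sapiens) for cytotoxicity, read by MTT assay (a lower number here means a stronger inhibitor, a higher number a weaker inhibitor), compound 1 (`O=c1oc2ccccc2c(O)c1-c1cc(-c2ccc(F)cc2)nc(O)n1`) gives 2390 nM, the lower of the two numbers measured so far, while compound 2 (`O=c1oc2ccccc2c(O)c1-c1cc(-c2c(F)cccc2Cl)nc(O)n1`) gives 5100 nM. Compound 3 (`O=c1oc2ccccc2c(O)c1-c1cc(-c2ccc(F)cc2)nc(S)n1`) departs from compound 1 at one place: sulfanyl in place of hydroxy on an aromatic carbon. For the measured compounds named here, the only measured step, a 2.1-fold higher number from compound 1 to compound 2 (0.33 log units; beyond the scatter), replaces the 4-fluorophenyl group and leaves the hydroxy untouched, so it offers only a rough sense of scale and no direction. No step beyond the scatter is therefore expected in this assay, and the estimated change is a 1.2-fold lower number from compound 1 to compound 3 (0.08 log units; within the scatter). Compound 3 is expected at 2000 nM, with an estimated range of 700 nM to 6000 nM.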

Compound 3, half-maximal inhibitory concentration: 21100 nM
Beside the measured number, compound 3's estimate is 11-fold (1.02 log units) below it; measured number outside the range, above it.
By their numbers in this assay, from the lowest: compound 1; then compound 2; then compound 3.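

In this assay, sulfanyl in place of hydroxy on the aromatic carbon between two ring nitrogen atoms gives an 8.8-fold higher number from compound 1 to compound 3 (0.95 log units; beyond the scatter). Among the compounds shown here, this is the first change at this position, and it shows that the number responds to the exchange of this single atom, although the entering and leaving groups match in hydrogen-bond donors and acceptors. No evidence is at hand to account for the size of this step. From the compounds shown here alone, whether an amine or a methoxy group here would stay near compound 1 remains open. So does whether the same exchange would give a similar step alongside the 2-chloro-6-fluorophenyl group of compound 2.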